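A few compounds are considered here, and "the series" means these few. Any claim that something is new, unique, unknown or untested is made for them only; others in the source may bear on it.

Measured compounds in the series:
compound 1, `O=C1C(Nc2ccc(I)cc2)=CC(=O)c2c1nc1n2[C@H]2OC[C@@H](O)[C@H]2OC1` — in a functional assay on ECa-109 cells for inhibition, with ECa-109 cell line (Homo sapiens) as the target, read by sulforhodamine B assay (on this read-out higher numbers stand for weaker inhibition and lower numbers for stronger inhibition), compound 1 gives 2530 nM
compound 2, `COc1ccc(NC2=CC(=O)c3nc4n(c3C2=O)[C@H]2OC[C@@H](O)[C@H]2OC4)cc1` — in this assay compound 2 gives > 4000 nM

For the measured compounds named here, compound 1 is the only compound of the two with a number in this assay. Compound 2 sits at the limit of > 4000 nM in this assay, at which 1 of the 2 values shown sits; the value for compound 2 is a limit of the assay and not a number, so the size of the gap between compound 2 and compound 1 cannot be read from it.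

Compound 3, `O=C1C(Nc2cccc(F)c2)=CC(=O)c2c1nc1n2[C@H]2OC[C@@H](O)[C@H]2OC1`, is not yet measured in this assay. It differs from compound 1 by 3-fluorophenyl in place of 4-iodophenyl on an amine nitrogen. Going by the values given here, no step between measured compounds bears on this change, so the expected step from compound 1 to compound 3 rests on compound 1 alone. The expectation is a step no larger than the scatter, or a small shift toward weaker inhibition, giving a 1.4-fold higher number from compound 1 to compound 3 (0.14 log units; within the scatter). For compound 3 the estimate in this assay is 3500 nM, with a range from 1500 nM to 8000 nM.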

Compound 3, half-maximal inhibitory concentration: 2370 nM
The estimate for compound 3 lay 1.5-fold (0.17 log units) above the measured number; the range from low to high includes it.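

In this assay, 3-fluorophenyl in place of 4-iodophenyl on an amine nitrogen gives a 1.1-fold lower number from compound 1 to compound 3 (0.03 log units; within the scatter). For the compounds shown here, this is the first readable comparison at this position: the two substituted phenyl groups, carrying different halogens at different ring positions, give values within the scatter of each other on the shared core. No measurement shown gives a cause for this step.

Steps to compound 2 cannot be read, as its value is a limit and not a number: the limit of > 4000 nM in this assay, at which 1 of the 3 values shown sits.

Still open, as far as these compounds go, is how a simple alkyl chain on this amine nitrogen, or a phenyl group carrying a carboxylic acid or an amine, would read in this assay.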